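Moving a Hydroxyl Group on a Shared Pyridine-Free Core Description

The compounds below may be only part of what the source reports. "The series", "measured", "known", "first", "only" and "open" are said of these compounds alone.

Of the compounds shown here, three have been tested in a functional assay on T47D cells (Homo sapiens) for cytotoxicity, read by CCK-8 assay and cell counting, with a stated time of 2 days; a higher number here means a weaker inhibitor, a lower number a stronger inhibitor. Compound 3 `Oc1cccc(-c2cc(-c3cccc(Cl)c3)nc(-c3cccs3)c2)c1` gives 3410 nM, compound 1 `Oc1ccc(-c2cc(-c3cccc(Cl)c3)nc(-c3cccs3)c2)cc1` gives 5350 nM, and compound 2 `Oc1cccc(-c2cc(-c3ccccc3)nc(-c3ccc(Cl)cc3)c2)c1` gives 11300 nM. The difference between compound 1 and compound 3 is 4-hydroxyphenyl in place of 3-hydroxyphenyl on an aromatic carbon, and that step made a 1.6-fold higher number from compound 3 to compound 1 (0.20 log units; within the scatter). How the core of compound 2 differs from the core of compound 3 is not broken down here.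

Compound 4 `Oc1ccc(-c2cc(-c3ccccc3)nc(-c3ccc(Cl)cc3)c2)cc1` has not yet been measured. It differs from compound 2 by 4-hydroxyphenyl in place of 3-hydroxyphenyl on an aromatic carbon. Around the place of change, compound 4 carries a 4-chlorophenyl group and a phenyl group where compound 1 carries a 3-chlorophenyl group and a thiophen-2-yl group, so this is the same kind of change, not the same. Because the earlier step gave a 1.6-fold higher number from compound 3 to compound 1 (0.20 log units; within the scatter), the step from compound 2 to compound 4 is expected to be about a 1.4-fold higher number from compound 2 to compound 4 (0.15 log units; within the scatter) in this assay. Compound 4 is therefore estimated at 16000 nM, likely between 7000 nM and 36000 nM.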

Compound 4, half-maximal inhibitory concentration: 4270 nM
Compound 4: middle estimate off by 3.7-fold (0.57 log units), on the high side; measured number below the stated range.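

In this assay the move from 3-hydroxyphenyl to 4-hydroxyphenyl gave a 2.6-fold lower number from compound 2 to compound 4 (0.42 log units; beyond the scatter) on the core of compound 2. The same change therefore did not carry over with the same size or direction, and a step measured on one core was a poor guide to the other: the same change on two cores in this assay, a 1.6-fold higher number (0.20 log units; within the scatter) from compound 3 to compound 1 and a 2.6-fold lower number (0.42 log units; beyond the scatter) from compound 2 to compound 4, 4.2-fold (0.62 log units) apart, beyond the scatter of two such steps.
This does not show which difference between the cores matters, the 4-chlorophenyl and phenyl groups of compound 4 or the 3-chlorophenyl and thiophen-2-yl groups of compound 1, and two cores cannot establish a rule for the series.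

A core carrying only one of these differences could separate their contributions. Also open, going by these compounds, is how either core would respond if an amine or a carboxylic acid took the place of the hydroxyl group.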